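The source may hold more compounds than are shown below. What is called first, only, known or untested is meant among the compounds shown, and "the series" means these compounds.

Measured so far in a functional assay on the whole organism for antagonist activity, with Mus musculus as the target; a lower number here means that less compound is needed, a higher number that more compound is needed for the effect
compound 1 `CCC(=O)N(c1ccc(Cl)cc1)C1CCCC1N(C)C` gives 0.2 mg/kg
compound 2 `CCC(=O)N(c1ccc(C)cc1)C1CCCC1N(C)C` gives 10 mg/kg; 10 mg/kg (2 entries)
compound 3 `CCC(=O)N(c1ccc(Br)cc1)C1CCCC1N(C)C` gives 3 mg/kg

Compound 3 at 3 mg/kg has a higher number than compound 1 and a lower number than compound 2. Compound 4 `CCC(=O)N(c1ccc(C(F)(F)F)cc1)C1CCCC1N(C)C` carries trifluoromethyl in place of bromo on an aromatic carbon and is still unmeasured. Going by the values given here, the one measured step at this place is a 15-fold higher number from compound 1 to compound 3 (1.18 log units; beyond the scatter) and is large, with bromo in place of chloro. Among the compounds with values here, it shows that a swap here can move the number far, but no trifluoromethyl compound has been measured, so it gives no direction. In this assay only a small net change is expected, with wide uncertainty, and the estimated step is a 1.3-fold higher number from compound 3 to compound 4 (0.12 log units; within the scatter) on that basis. For compound 4 the estimate is 4 mg/kg with an expected range of 0.7 mg/kg to 20 mg/kg for now.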

Compound 4, dose for half-maximal effect: 25 mg/kg
Estimate against measurement, compound 4: 6.3-fold (0.80 log units) below; measured number above the stated range.
By their numbers in this assay, from the lowest: compound 1; then compound 3; then compound 4.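

At this aromatic carbon in this assay, trifluoromethyl gives an 8.3-fold higher number from compound 3 to compound 4 (0.92 log units; beyond the scatter) and, measured against chloro, a 130-fold higher number from compound 1 to compound 4 (2.10 log units; beyond the scatter) in the same series. The span at this one place is therefore wider than the bromo-for-chloro step alone showed, and among compound 1, compound 3 and compound 4 the chloro compound keeps the lowest number. No measurement is available that bears on the reason for this order. Open, going by these compounds, is where a nitrile, a methoxy group or an amine at this carbon would fall, and whether any group gives a lower number than chloro.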